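The source may hold more compounds than are shown below. What is called first, only, known or untested is meant among the compounds shown, and "the series" means these compounds.

Working notes on the series. Compound 1 `CC(C)(C)c1ccc(C(=O)N2CCC3(CC2)C(=O)N(CC(=O)N2CCC(CCO)CC2)CN3c2ccccc2)cc1` gives 2600 nM in an assay on HEK293 cells for displacement of a labelled ligand from NPC1-like intracellular cholesterol transporter 1 (Homo sapiens); on this read-out lower numbers stand for stronger inhibition and higher numbers for weaker inhibition. Among the compounds with values here, compound 3 `CC(C)(C)c1ccc(C(=O)N2CCC3(CC2)C(=O)N(CC(=O)NCCO)CN3c2ccccc2)cc1` gives 1000 nM, and the step of a 2.6-fold lower number from compound 1 to compound 3 (0.41 log units; beyond the scatter) is the only single change so far measured. Compound 2 `CCOC(=O)C1CCN(C(=O)CN2CN(c3ccccc3)C3(CCN(C(=O)c4ccc(C5CCCCC5)cc4)CC3)C2=O)CC1` gives 900 nM, the lowest of the three numbers; the value of compound 3 sits within the scatter of it, while that of compound 1 lies beyond.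

Compound 4 `COC(=O)CCCNC(=O)CN1CN(c2ccccc2)C2(CCN(C(=O)c3ccc(C4CCCCC4)cc3)CC2)C1=O` differs from compound 2 by (3-(methoxycarbonyl)propyl)amino in place of 4-(ethoxycarbonyl)piperidin-1-yl on a carbonyl carbon, a group with no ring in place of one with a six-membered non-aromatic ring. The measured step that bears on this is a 2.6-fold lower number from compound 1 to compound 3 (0.41 log units; beyond the scatter), a similar exchange on a carbonyl carbon. A step of comparable direction and modest size in this assay is therefore expected, a 1.8-fold lower number from compound 2 to compound 4 (0.26 log units; within the scatter). For compound 4 the estimated value in this assay is 500 nM, in the range 200 nM to 1300 nM.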

Compound 4, half-maximal inhibitory concentration: 2500 nM
Compound 4: the middle estimate sits 5.0-fold (0.70 log units) below what was measured; measured number above the stated range.
By their numbers in this assay, from the lowest: compounds 2 and 3 (each within the scatter of the next); then compounds 4 and 1 (each within the scatter of the next).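

In this assay, a 2.8-fold higher number from compound 2 to compound 4 (0.44 log units; beyond the scatter), opposite in direction to a 2.6-fold lower number from compound 1 to compound 3 (0.41 log units; beyond the scatter). A group with no ring in place of one with a six-membered non-aromatic ring therefore does not by itself set the direction of change on this carbonyl carbon. No measurement available here accounts for the reversal.

Going by these compounds, whether the reversal follows the ester or hydroxyl ending of the group, or the tert-butyl or cyclohexyl group elsewhere in the compounds, remains open. So does the effect of a carboxylic acid in place of the methyl ester of the chain.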